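Side Chain Swap on a Scaffold Already at the Limit

This account rests on a few compounds, and the source may have more. Where it says the series, first, only, none or still open, it means among the compounds named here.

Going by the values given here, both compounds measured so far sit at the floor of detection in an assay on HEK293 cells for displacement of a labelled ligand from MAP/microtubule affinity-regulating kinase 4 (Homo sapiens), read by NanoBRET; a lower number here means a stronger inhibitor, a higher number a weaker inhibitor. Compound 1 `O=C(NCCCNc1ccnc(Nc2cccc(NC(=O)N3CCCC3)c2)n1)C1CCC1` returns only a limit in this assay, > 10000 nM. Compound 2 `NS(=O)(=O)c1ccc(CNc2nc(Nc3cccc(NC(=O)N4CCCC4)c3)ncc2C2CC2)cc1` likewise returns only a limit in this assay, > 10000 nM. Among the compounds with values here, compound 2 therefore stands exactly where every value shown stands, as the limit of > 10000 nM in this assay, at which 2 of the 2 values shown sit, records, and because compound 1 and compound 2 differ in more than one place no measured step links them; their two values show only that both are limits.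

Compound 3 `O=C(NCCCNc1nc(Nc2cccc(NC(=O)N3CCCC3)c2)ncc1C1CC1)C1CCC1` keeps the core of compound 2 and differs from it in a single place: 2-((cyclobutylcarbonyl)amino)ethyl in place of 4-sulfamoylphenyl on a saturated chain carbon bound to a nitrogen on an aromatic ring. Within the data shown here, the chain that enters is the one already carried by compound 1, whose value in this assay is itself a limit.

With both neighbours at the limit, no step beyond the scatter is expected in this assay, and the expected change is a step that the limit leaves unreadable from compound 2 to compound 3. Compound 3 is accordingly estimated to give 15000 nM in this assay, with a range from 4000 nM to 50000 nM, most probably reported again as a limit rather than as a number.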

Compound 3, half-maximal inhibitory concentration: 509 nM
Beside the measured number, compound 3's estimate is 29-fold (1.47 log units) above it; the whole stated range lies above it.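

In this assay, the side chain on a saturated chain carbon bound to a nitrogen on an aromatic ring proves able to decide whether a number can be read at all: 2-((cyclobutylcarbonyl)amino)ethyl in place of 4-sulfamoylphenyl gives an at least 19-fold lower number from compound 2 to compound 3 (1.29 log units; beyond the scatter). The same chain does not suffice by itself, since cyclopropyl in place of hydrogen on an aromatic carbon gives an at least 19-fold lower number from compound 1 to compound 3 (1.29 log units; beyond the scatter), and so this second place matters as well. Among the compounds shown, only the one carrying both the cyclopropyl and this chain leaves the limit, while each of the other two lacks one of them: the limit of > 10000 nM in this assay, at which 2 of the 3 values shown sit.

Going by these compounds, both steps start from a limit, so their full size stays unknown, and the three compounds cannot show how much of the gain belongs to the cyclobutyl carbonyl and how much to the chain that carries it. Also open, on these data alone, is whether a longer chain, an amine or a carboxylic acid at the end of the chain, or a methyl or chlorine in place of the cyclopropyl would keep a readable number.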